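Two Compounds at the Limit, One Stereocentre Untested

A few compounds are considered here, and "the series" means these few. Any claim that something is new, unique, unknown or untested is made for them only; others in the source may bear on it.

Measured in a functional assay on BXPC-3 cells (Homo sapiens) for antiproliferative activity, read by MTT assay, with a stated time of 24 h; a lower number here means a stronger inhibitor, a higher number a weaker inhibitor:
- compound 1 `CCn1c(C(=O)NCC(=O)O)ccc1C(CC)(CC)c1ccc(OCS(=O)(=O)c2ccccc2)c(C)c1`: > 50000 nM (a limit)
- compound 2 `CCn1c(C(=O)N[C@@H](CC(=O)O)C(=O)O)ccc1C(CC)(CC)c1ccc(OCS(=O)(=O)c2ccccc2)c(C)c1`: > 50000 nM (a limit)

Neither entry is a true number. Compound 2 stands at the edge of what this assay reports, with > 50000 nM as its limit. The same holds across the whole small set (the limit of > 50000 nM in this assay, at which 2 of the 2 values shown sit), so no ranking of the two compounds can be drawn.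

Compound 3 `CCn1c(C(=O)N[C@H](CC(=O)O)C(=O)O)ccc1C(CC)(CC)c1ccc(OCS(=O)(=O)c2ccccc2)c(C)c1` keeps every atom and bond of compound 2. The only difference is this: the two compounds have the same atoms and bonds and differ only in configuration as drawn: 1 of 1 stereo elements differ; a stereocentre at a saturated chain carbon is drawn S in compound 2 and R in compound 3. Nothing leaves and nothing enters.

Within the data shown here, the one measured step, a step that the two limits leave unreadable from compound 1 to compound 2, has no readable size, and no measured pair tests a change of configuration. The data therefore give no reason to expect a gain in potency or a loss, and no direction can be assigned. The expected step of a number no higher from compound 2 to compound 3 (the limit leaves the size open) is none that could be read. This expectation rests on compound 2 with > 50000 nM as its limit. Compound 3 is estimated at 50000 nM with an expected range of 20000 nM to 100000 nM and will probably be reported only as a limit.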

Compound 3, half-maximal inhibitory concentration: > 50000 nM
Compound 3 gave a limit, no number; the forecaster's own chance of this, stated with the estimate: 85%; the middle value lies on the limit itself.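

In this assay compound 3 gives > 50000 nM as a limit, not a number. Among these compounds, no step among compound 1, compound 2 and compound 3 can be read, because all three stand at the same limit: the limit of > 50000 nM in this assay, at which 3 of the 3 values shown sit.

Going by these compounds, what stays open is how potent these compounds truly are, and whether the configuration at the stereocentre of compound 2 and compound 3 makes any difference.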